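The source may report more compounds than this note shows. Statements on the series, on what has been measured and on what is new or still open speak of the compounds shown alone.

Among the three measured compounds, compound 1 `Cc1ccc(OCCCCOc2ccc(C(=O)CC(C)(C)C)c(O)c2C)cc1C(=O)O` gives the lowest number: in an assay for positive allosteric modulation of metabotropic glutamate receptor 3 (Rattus norvegicus) (a lower number here means that less compound is needed, a higher number that more compound is needed for the effect), compound 1 gives 309 nM. Compound 2 `COc1cc(OCCCCOc2ccc(C(=O)CC(C)(C)C)c(O)c2C)cc(C(=O)O)c1` gives 703 nM in this assay, and compound 3 `Cc1c(OCCCCOc2ccc(C(=O)O)cc2F)ccc(C(=O)CC(C)(C)C)c1O` gives 1230 nM. For the measured compounds named here, the only step between two compounds that differ in a single place is a 4.0-fold higher number from compound 1 to compound 3 (0.60 log units; beyond the scatter), a modest loss when 4-carboxy-2-fluorophenyl replaces 3-carboxy-4-methylphenyl on the oxygen on a saturated carbon.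

Compound 4 `Cc1c(OCCCCOc2ccc(F)c(C(N)=O)c2)ccc(C(=O)CC(C)(C)C)c1O` is not yet measured. It differs from compound 1 as follows: 3-carbamoyl-4-fluorophenyl in place of 3-carboxy-4-methylphenyl on an oxygen on a saturated carbon. The carboxylic acid of compound 1 is thus exchanged for a carbamoyl group and the methyl for a fluorine, while the donor and acceptor count and the ring stay as they were. The step from compound 1 to compound 3, which likewise introduced a fluorine and moved the acid, cost a 4.0-fold higher number from compound 1 to compound 3 (0.60 log units; beyond the scatter); compound 2, with a different ring substitution, also sits above compound 1. On this basis a modest rise in the number is expected for compound 4, of about a 2.9-fold higher number from compound 1 to compound 4 (0.46 log units; beyond the scatter) in this assay. Compound 4 is therefore estimated at 900 nM, with a plausible range from 300 nM to 3000 nM.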

Compound 4, half-maximal effective concentration: "not active" (no number reported)
Compound 4 has no reported number here, and the estimate cannot be compared.
By their numbers in this assay, from the lowest: compound 1; then compounds 2 and 3 (each within the scatter of the next).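

For the compounds shown here, compound 4 is reported as "not active" in this assay, with no number, so no step from compound 1 to compound 4 can be read. No available evidence bears on this result. The compounds shown leave open whether the carbamoyl group, the fluorine, or the two together lie behind it.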